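Replacing the Chloro Group on Compound 3 with an Arylamine

The source may hold more compounds than are shown below. What is called first, only, known or untested is meant among the compounds shown, and "the series" means these compounds.

Compound 1, `CCOc1ccc(C(=O)Nc2cc(C)cc(C)n2)cc1`: 17100 nM
Compound 2, `C=CCOc1ccc(C(=O)Nc2cccc(Br)n2)cc1`: 70100 nM
Compound 3, `CCCOc1ccc(C(=O)Nc2cccc(Cl)n2)cc1`: > 100000 nM

Of the compounds shown here, three have been measured in an in vitro assay on HEK-tsA201 cells for antagonist activity at Neuronal acetylcholine receptor; alpha4/beta2 (Homo sapiens), read by fluorescence and calcium flux; a higher number here means a weaker inhibitor, a lower number a stronger inhibitor. Compound 1 gives 17100 nM and compound 2 gives 70100 nM. For compound 3 only a limit is known: in this assay compound 3 is reported at > 100000 nM, which is the limit of > 100000 nM in this assay, at which 1 of the 3 values shown sits, so compound 3 stands at the edge of what the measurement can report, with no number of its own.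

Compound 4, `CCCOc1ccc(C(=O)Nc2cccc(Nc3ccc(OC)cc3)n2)cc1`, has not yet been measured. It differs from compound 3 in one place: (4-methoxyphenyl)amino in place of chloro on an aromatic carbon. Among the compounds with values here, no step between two measured compounds is available to calibrate this change, so any expectation rests on the position of compound 3 alone.

Since compound 3 already sits at a limit, a step from compound 3 to compound 4 cannot be worse than the scatter in a way the assay would show; the author expects a step of an at least 3.3-fold lower number from compound 3 to compound 4 (0.52 log units; beyond the scatter) toward a stronger inhibitor, though with little confidence. Compound 4 is therefore estimated at 30000 nM, with a range from 5000 nM to 100000 nM.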

Compound 4, half-maximal inhibitory concentration: > 100000 nM
Compound 4: a limit, no number; the forecaster's own chance of this, stated with the estimate: 30%; middle value at least 3.3-fold (0.52 log units) away from the limit.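

In this assay compound 4 gives > 100000 nM, which is a limit and not a number. Within the data shown here, compound 3 also stands at a limit, so no step between compound 3 and compound 4 can be read: the limit of > 100000 nM in this assay, at which 2 of the 4 values shown sit. The compounds shown leave open whether (4-methoxyphenyl)amino in place of chloro changes inhibitor strength at all.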